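From 2-chlorobenzyl to 4-chlorobenzyl on a Shared Core

The source may hold more compounds than are shown below. What is called first, only, known or untested is meant among the compounds shown, and "the series" means these compounds.

Of the compounds shown here, three built on one shared core have been measured in a functional assay on the whole organism (artery, strain albino) with Rattus norvegicus as the target, with a stated time of 30 min, at a dose of 10 mg/kg by the oral route; a higher number here means more inhibition at the dose given (going by the name of the read-out), a lower number less inhibition. Compound 1 `COc1ccc(C2N=C(SCc3cccc(Cl)c3)NC(C)=C2C(=O)Nc2ccc(F)cc2)cc1OC` gives 5.2%. Compound 2 `CC1=C(C(=O)Nc2ccc(F)cc2)C(c2ccc([N+](=O)[O-])cc2)N=C(SCc2ccccc2Cl)N1` gives 3.1%. Compound 3 `CC1=C(C(=O)Nc2ccc(Br)cc2)C(c2ccc(Cl)cc2Cl)N=C(SCc2ccccc2Cl)N1` gives 5.7%, the highest of the three numbers, yet all three lie within the scatter of one another, so no order among them can be read. Compound 4 `CC1=C(C(=O)Nc2ccc(Br)cc2)C(c2ccc(Cl)cc2Cl)N=C(SCc2ccc(Cl)cc2)N1` has not yet been measured in this assay. It differs from compound 3 in one place: 4-chlorophenyl in place of 2-chlorophenyl on a saturated chain carbon bound to a sulfur. Among the compounds with values here, no measured pair differs in this way alone, and the measured values barely spread, so there is nothing to point to a step in either direction. The step of a number 0.7 percentage points lower from compound 3 to compound 4 (within the scatter) is expected to stay within the scatter. Compound 4 is estimated to give 5%, with a range from 0% to 13%.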

Compound 4, a percentage reported as inhibition, in the whole organism at one dose (the size of the read-out at that dose, not a potency): 6.7%
Compound 4: middle estimate off by 1.7 percentage points, on the low side; measured number inside the range.
By their numbers in this assay, from the lowest: compounds 2, 1, 3 and 4 (each within the scatter of the next).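

In this assay, moving the chlorine from 2-chlorobenzyl to 4-chlorobenzyl on the sulfur gives a number 1 percentage points higher from compound 3 to compound 4 (within the scatter). Within the data shown here, this is the first comparison of compounds that differ in one place only, and it shows that this read-out at this dose does not separate these two groups. Nothing measured here bears on why the two compounds read alike. Still open, going by these compounds, is whether a different group at this place would leave the scatter, such as an amine or a carboxylic acid on the phenyl ring, or a longer chain on the sulfur.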